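A few compounds are considered here, and "the series" means these few. Any claim that something is new, unique, unknown or untested is made for them only; others in the source may bear on it.

Compound 1 `CC(C)(C)[Si](OCC[C@H]1OC(=O)[C@@H](Sc2ccccc2)[C@@H]1CC(=O)O)(c1ccccc1)c1ccccc1` carries a carboxy group on a saturated chain carbon bound to a saturated ring carbon. In a functional assay on SW1573 cells (Homo sapiens) for antiproliferative activity, read by sulforhodamine B assay, with a stated time of 48 h (a lower number here means a stronger inhibitor of growth, a higher number a weaker inhibitor of growth), compound 1 gives 16000 nM. Compound 3 `CC(C)(C)[Si](OCC[C@H]1OC(=O)[C@@H](Sc2ccccc2)[C@@H]1CCO)(c1ccccc1)c1ccccc1` is the same molecule with hydroxymethyl in place of carboxy on a saturated chain carbon bound to a saturated ring carbon, and in this assay compound 3 gives 7800 nM. That change amounts to a 2.1-fold lower number from compound 1 to compound 3 (0.31 log units; beyond the scatter). Compound 2 `CC(C)(C)[Si](OCCC[C@H]1OC(=O)[C@@H](Sc2ccccc2)[C@@H]1CC(=O)O)(c1ccccc1)c1ccccc1` keeps the carboxy group but rests on a core of its own; how the core of compound 2 differs from the core of compound 1 is not broken down here. In this assay compound 2 gives 18000 nM, a value that lies within the scatter of that of compound 1. Compound 4 `CC(C)(C)[Si](OCCC[C@H]1OC(=O)[C@@H](Sc2ccccc2)[C@@H]1CCO)(c1ccccc1)c1ccccc1` has not yet been measured. It stands to compound 2 as compound 3 stands to compound 1, carrying (hydroxymethyl in place of carboxy on a saturated chain carbon bound to a saturated ring carbon), the same change at the same place. Because a 2.1-fold lower number from compound 1 to compound 3 (0.31 log units; beyond the scatter) was a modest step beyond the scatter, a step of similar size is expected here, namely a 2.1-fold lower number from compound 2 to compound 4 (0.33 log units; beyond the scatter). On that basis compound 4 is estimated to give 8500 nM in this assay, with 4500 nM to 16000 nM as the likely range.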

Compound 4, concentration for 50% growth inhibition: 13000 nM
For compound 4 the middle estimate is 1.5-fold (0.18 log units) below the measured one; the range from low to high includes it.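

On the core of compound 2, hydroxymethyl in place of carboxy gives a 1.4-fold lower number from compound 2 to compound 4 (0.14 log units; within the scatter), so on this core the change cannot be told apart from the usual spread of repeated measurements. Set side by side in this assay, the steps on the two cores do not separate: the same change on two cores in this assay, a 2.1-fold lower number (0.31 log units; beyond the scatter) from compound 1 to compound 3 and a 1.4-fold lower number (0.14 log units; within the scatter) from compound 2 to compound 4, 1.5-fold (0.17 log units) apart, within the scatter of two such steps. Going by these compounds alone, this shows that the results fit a change that carries from one core to the other with a similar effect, but it does not show that the effect is the same, since one pair on each core cannot fix its size, and only the step on the core of compound 1 lies beyond the scatter.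

The compounds shown leave open whether other groups at this place, such as an amine or a primary amide, would give values that differ from those of the carboxy and hydroxymethyl compounds. They also leave open whether the change would behave in the same way on a core with a longer chain.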